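A few compounds are considered here, and "the series" means these few. Any claim that something is new, unique, unknown or untested is made for them only; others in the source may bear on it.

Measured so far:
- compound 1 `CCOC(=O)c1cnn2c1N(C(=O)Nc1cccc3ccccc13)C(c1ccccc1)C2`: 206 nM
- compound 2 `NC(=O)c1cnn2c1N(C(=O)Nc1cccc(F)c1)C(c1ccccc1)C2`: 1.2 nM

In a functional assay on cells (Neutrophil, Homo sapiens) for inhibition, with a stated time of 10 min (on this read-out lower numbers stand for stronger inhibition and higher numbers for weaker inhibition), compound 2 stands lowest at 1.2 nM, making it the stronger inhibitor of the pair, while compound 1 gives 206 nM, a gap beyond the usual scatter.

Compound 3 `NC(=O)c1cnn2c1N(C(=O)Nc1cccc3ccccc13)C(c1ccccc1)C2` has not yet been measured. It is compound 2 with naphthalen-1-yl in place of 3-fluorophenyl on an amide-type nitrogen.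

For the measured compounds named here, no measured pair isolates this change. Compound 1 also carries naphthalen-1-yl, but it differs from compound 3 elsewhere too, so the value of compound 1, 206 nM, is only a loose guide. On that guide, weaker inhibition is expected, with an estimated 21-fold higher number from compound 2 to compound 3 (1.32 log units; beyond the scatter) in this assay. The estimate for compound 3 is 25 nM, with an expected range of 2.5 nM to 250 nM.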

Compound 3, half-maximal inhibitory concentration: > 1000 nM
Compound 3: no number, only a limit; the forecaster's own chance of this, stated with the estimate: 5%; at least 40-fold (1.60 log units) between middle value and limit.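

In this assay, putting naphthalen-1-yl in place of 3-fluorophenyl on the amide-type nitrogen, with the rest of the molecule unchanged, gives an at least 830-fold higher number from compound 2 to compound 3 (2.92 log units; beyond the scatter), so inhibition depends strongly on the group at this position. Compound 3 has no exact number, only a limit: the limit of > 1000 nM in this assay, at which 1 of the 3 values shown sits. With naphthalen-1-yl in place on both compounds, amino in place of ethoxy on the carbonyl carbon gives an at least 4.8-fold higher number from compound 1 to compound 3 (0.68 log units; beyond the scatter), so amino does not bring stronger inhibition by itself, and the low number of compound 2 cannot be credited to amino alone.

The compounds shown leave open whether a plain phenyl or a 3-chlorophenyl would hold inhibition at this position as 3-fluorophenyl does. They also leave open how ethoxy on the carbonyl carbon behaves alongside 3-fluorophenyl.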